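Butyl in place of bromo on a cinnamamide series

The source may report more compounds than this note shows. Statements on the series, on what has been measured and on what is new or still open speak of the compounds shown alone.

Going by the values given here, compound 2 `CCCc1cc(N)c2cc(NC(=O)/C=C/c3ccc(Br)cc3)ccc2n1` gives 93 nM in a functional assay on HEK293 cells for activation of melanin-concentrating hormone receptor 1 (Homo sapiens), read by inositol phosphate accumulation (on this read-out lower numbers stand for an effect already at smaller amounts and higher numbers for an effect only at larger amounts of compound), the lowest of the two numbers measured so far. Its neighbour, compound 1 `CCCc1cc(N)c2cc(NC(=O)/C=C/c3ccc(F)cc3)ccc2n1`, gives 200 nM in this assay; the step from compound 1 to compound 2, bromo in place of fluoro on an aromatic carbon, gave a 2.2-fold lower number from compound 1 to compound 2 (0.33 log units; beyond the scatter). Compound 3 `CCCCc1ccc(/C=C/C(=O)Nc2ccc3nc(CCC)cc(N)c3c2)cc1` is not yet measured; it differs from compound 2 by butyl in place of bromo on an aromatic carbon. Among the compounds with values here, the only step available bears on this change indirectly: it shows a modest gain when the group at this place grew from fluoro to bromo, but no measured step covers butyl at this place. On that basis a step of similar modest size, or none beyond the scatter, is expected, and compound 3 is estimated at 70 nM (range 20 nM to 300 nM), meaning an expected step of a 1.3-fold lower number from compound 2 to compound 3 (0.12 log units; within the scatter).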

Compound 3, half-maximal effective concentration: 740 nM
Compound 3: the middle estimate sits 11-fold (1.02 log units) below what was measured; the measured number lies above the stated range.
By their numbers in this assay, from the lowest: compound 2; then compound 1; then compound 3.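

In this assay, butyl on this aromatic carbon, para to a large group, gave an 8.0-fold higher number from compound 2 to compound 3 (0.90 log units; beyond the scatter) and, set against the fluoro compound, a 3.7-fold higher number from compound 1 to compound 3 (0.57 log units; beyond the scatter). The lower number seen on going from fluoro to bromo therefore does not continue when the group here grows to butyl, with 4 heavy atoms against 1 for bromo, and compound 3 has the highest number of the three. Nothing at hand explains this rise.

The compounds shown leave open whether a shorter chain, such as methyl or ethyl, would give a number nearer those of the two halogen compounds or nearer that of compound 3. They also leave open how a group carrying oxygen or nitrogen, such as methoxy or an amine, would behave at this place.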